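Swapping a Heptyl Chain for a Trifluoromethoxyphenyl Ring

A few compounds are considered here, and "the series" means these few. Any claim that something is new, unique, unknown or untested is made for them only; others in the source may bear on it.

Compound 1 `CCCCCCCc1cn(C(c2ccccc2)c2cc3cc(Br)ccc3nc2OC)nn1` was tested in an ADME assay on PANC-1 cells (Homo sapiens) for cytotoxicity, read by sulforhodamine B assay, with a stated time of 48 h, tested at 10 uM (on this read-out higher numbers stand for more inhibition at the one concentration tested (going by the name of the read-out) and lower numbers for less inhibition), where compound 1 gives 16.6%. Among the three measured compounds this number is the second highest: compound 2 `COc1nc2ccc(Br)cc2cc1C(c1ccccc1)n1cc(-c2ccccc2F)nn1` gives 14.7%, a step of a number 1.9 percentage points lower from compound 1 to compound 2 (within the scatter), and compound 3 `COc1nc2ccc(Br)cc2cc1C(c1ccccc1)n1cc(CCCO)nn1` gives 25.5%, a step of a number 8.9 percentage points higher from compound 1 to compound 3 (within the scatter). Only a number 10.8 percentage points higher from compound 2 to compound 3 (beyond the scatter) reaches beyond the scatter.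

Compound 4 `COc1nc2ccc(Br)cc2cc1C(c1ccccc1)n1cc(-c2ccc(OC(F)(F)F)cc2)nn1` differs from compound 1 in one place: 4-(trifluoromethoxy)phenyl in place of heptyl on an aromatic carbon. Among the compounds with values here, the nearest precedent is a number 1.9 percentage points lower from compound 1 to compound 2 (within the scatter), where 2-fluorophenyl replaced heptyl and the number stayed within the scatter. A similar outcome is expected here, so compound 4 is estimated at 15%, between 5% and 27%. The expected step is a number 1.6 percentage points lower from compound 1 to compound 4 (within the scatter), which would lie within the scatter.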

Compound 4, a percentage reported as inhibition, at one concentration (the size of the read-out at that concentration, not a potency): 11.7%
For compound 4 the middle estimate is 3.3 percentage points above the measured one; low and high end bracket the measured number.
By their numbers in this assay, from the lowest: compounds 4, 2, 1 and 3 (each within the scatter of the next, the first and the last beyond it).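

In this assay, the larger 4-(trifluoromethoxy)phenyl ring gives no separable change from the heptyl chain (a number 4.9 percentage points lower from compound 1 to compound 4 (within the scatter)) or from the 2-fluorophenyl ring (a number 3 percentage points lower from compound 2 to compound 4 (within the scatter)). Both rings now sit apart from the 3-hydroxypropyl group, with the new ring showing (a number 13.8 percentage points lower from compound 3 to compound 4 (beyond the scatter)), although compound 1 lies within the scatter of all three others. Nothing measured here explains this difference.

On these data alone, it remains open whether the hydroxy group of compound 3 matters or only its chain. An amine or a carboxylic acid in its place would help separate the two.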